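Anilinopyrimidine imines: phenyl for ethoxycarbonyl at the imine carbon

This account rests on a few compounds, and the source may have more. Where it says the series, first, only, none or still open, it means among the compounds named here.

Measured so far in a functional assay on MCF7 cells (Homo sapiens) for antiproliferative activity, read by MTT assay; a higher number here means a weaker inhibitor, a lower number a stronger inhibitor:
- compound 1, `CCOC(=O)/C=N/c1cnc(Nc2ccc(S(N)(=O)=O)cc2)nc1NC1CCCC1`: 42200 nM
- compound 2, `NS(=O)(=O)c1ccc(Nc2ncc(/N=C/c3ccccc3)c(NC3CCCC3)n2)cc1`: 39100 nM
- compound 3, `CCOC(=O)/C=N/c1cnc(Nc2ccc(N3CCN(C)CC3)cc2)nc1NC(C)C`: 12300 nM

Compound 3 gives the lowest number of the three; its gap to compound 1 and to compound 2 lies beyond the scatter. The difference between the core of compound 3 and the core of compound 1 is not broken down here.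

Compound 1 and compound 2 differ by phenyl in place of ethoxycarbonyl on a carbon with a double bond to nitrogen, and this gave a 1.1-fold lower number from compound 1 to compound 2 (0.03 log units; within the scatter).

Compound 4, `CC(C)Nc1nc(Nc2ccc(N3CCN(C)CC3)cc2)ncc1/N=C/c1ccccc1`, is not yet measured. It differs from compound 3 by phenyl in place of ethoxycarbonyl on a carbon with a double bond to nitrogen, the same change made from compound 1 to compound 2. Because that step was a 1.1-fold lower number from compound 1 to compound 2 (0.03 log units; within the scatter), compound 4 is expected to sit close to compound 3 in this assay, the expected step being a 1.1-fold lower number from compound 3 to compound 4 (0.03 log units; within the scatter). The estimate for compound 4 is 11500 nM, between 5500 nM and 24000 nM.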

Compound 4, half-maximal inhibitory concentration: > 100000 nM
Compound 4: no number, only a limit; the forecaster's own chance of this, stated with the estimate: 5%; at least 8.6-fold (0.93 log units) between middle value and limit.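

In this assay compound 4 gives > 100000 nM, which is a limit of the assay and not a number. Phenyl in place of ethoxycarbonyl on a carbon with a double bond to nitrogen does not carry over from one core to the other, the new step being an at least 8.1-fold higher number from compound 3 to compound 4 (0.91 log units; beyond the scatter), and the two steps differ: the same change on two cores in this assay, a 1.1-fold lower number (0.03 log units; within the scatter) from compound 1 to compound 2 and an at least 8.1-fold higher number (0.91 log units; beyond the scatter) from compound 3 to compound 4, at least 8.7-fold (0.94 log units) apart, beyond the scatter of two such steps. Among these compounds, with only two pairs, this does not show which feature of the cores accounts for the gap, and the new step has no upper end: the limit of > 100000 nM in this assay, at which 1 of the 4 values shown sits.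

The compounds shown do not separate the differences between the core of compound 1 and the core of compound 3. As far as these compounds go, how a carboxylic acid or an amide in that place would behave on either core remains open.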